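Swapping a hydroxyl chain for a basic amine chain

The source may report more compounds than this note shows. Statements on the series, on what has been measured and on what is new or still open speak of the compounds shown alone.

Of the compounds shown here, three with a shared core have been tested in an assay on HEK293 cells for inhibition of Steryl-sulfatase (Homo sapiens), tested at 1 uM; on this read-out lower numbers stand for a weaker effect and higher numbers for a stronger effect at the one concentration tested. Compound 1 `CCN(Cc1ccccc1)Cc1ccc(CN2CCc3ccc(OS(N)(=O)=O)cc3C2)cc1` gives 17% in this assay. Compound 2 `CCN(Cc1ccc(F)cc1)c1cccc(C(=O)N2CCc3ccc(OS(N)(=O)=O)cc3C2)c1` gives 66.5% in this assay. Compound 3 `NS(=O)(=O)Oc1ccc2c(c1)CN(C(=O)c1ccc(N(CCCO)Cc3ccccc3)cc1)CC2` gives 64.3% in this assay, the second highest of the three numbers; its value and that of compound 2 lie within the scatter of each other, while compound 1 sits well below it, beyond the scatter.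

Compound 4 `CN(C)CCN(Cc1ccccc1)c1ccc(C(=O)N2CCc3ccc(OS(N)(=O)=O)cc3C2)cc1` is not yet measured. It differs from compound 3 in one place: dimethylamino in place of hydroxymethyl on a saturated chain carbon, two bonds along the chain from a nitrogen on an aromatic ring. Among the compounds with values here, no comparable single change between measured compounds is available, so there is no step to lean on. The two measured amide compounds, compound 2 and compound 3, both sit in the same high band despite different substituents on the aromatic nitrogen, which suggests that this change may leave the number roughly where it is.

The expected step from compound 3 to compound 4, a number 4.3 percentage points lower from compound 3 to compound 4 (within the scatter), is small and within the scatter, in no firm direction. Compound 4 is therefore estimated at 60%, with a range from 40% to 78%.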

Compound 4, a percentage reported as inhibition, at one concentration (the size of the read-out at that concentration, not a potency): 57.8%
For compound 4 the middle estimate is 2.2 percentage points above the measured one; low and high end bracket the measured number.
By their numbers in this assay, from the lowest: compound 1; then compounds 4, 3 and 2 (each within the scatter of the next).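

In this assay, exchanging the 3-hydroxypropyl chain for a 2-(dimethylamino)ethyl chain gives a number 6.5 percentage points lower from compound 3 to compound 4 (within the scatter) and is the only single change among these compounds that can be read directly. It shows that at this place, on a saturated chain carbon two bonds along the chain from a nitrogen on an aromatic ring, hydroxymethyl, which has a hydrogen-bond donor, can be exchanged for dimethylamino, which has none, without the number moving beyond the scatter. Nothing available here offers an explanation for this result.

The compounds shown leave open whether a carboxylic acid, a morpholine or a longer chain at this place would stay within the scatter of compound 3. They also leave open whether the same exchange would give a similar step on compound 2, which differs from compound 3 in more than one place.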